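Methyl Substitution on a Fused Core: Growth Inhibition Data

The compounds below may be only part of what the source reports. "The series", "measured", "known", "first", "only" and "open" are said of these compounds alone.

Measured so far:
- compound 1 `COc1ccc(-c2cc(O)c3cccnc3n2)cc1`: 31600 nM
- compound 2 `COc1ccccc1-c1cc(O)c2cccnc2n1`: 29500 nM
- compound 3 `COc1ccc(-c2cc(O)c3ccc(C)nc3n2)cc1`: > 100000 nM (a limit)

All three were tested in a functional assay on PC-3 cells (Homo sapiens); on this read-out higher numbers stand for weaker inhibition of growth and lower numbers for stronger inhibition of growth. In this assay compound 1 gives 31600 nM and compound 2 gives 29500 nM; these two values lie within the scatter of each other. Compound 3 gives > 100000 nM in this assay, which is a limit of the assay rather than a number.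

Compound 3 differs from compound 1 by methyl in place of hydrogen on an aromatic carbon. This change gives an at least 3.1-fold higher number from compound 1 to compound 3 (0.50 log units; beyond the scatter), a step that rests in part on (the limit of > 100000 nM in this assay, at which 1 of the 3 values shown sits).

Compound 4 `COc1ccccc1-c1cc(O)c2cc(C)cnc2n1` has not yet been measured. It differs from compound 2 by methyl in place of hydrogen on an aromatic carbon. The difference between the cores of compound 1 and compound 2 is not broken down here. The change from compound 2 to compound 4 is the same kind of change as that from compound 1 to compound 3, but the methyl now sits two atoms from the ring nitrogen rather than next to the ring nitrogen. Compound 4 is expected to show a 2.4-fold higher number from compound 2 to compound 4 (0.38 log units; beyond the scatter), because the same kind of change gave an at least 3.1-fold higher number from compound 1 to compound 3 (0.50 log units; beyond the scatter). The estimate for compound 4 in this assay is 70000 nM, expected to fall between 25000 nM and 150000 nM.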

Compound 4, concentration for 50% growth inhibition: 26900 nM
Beside the measured number, compound 4's estimate is 2.6-fold (0.42 log units) above it; measured number inside the range.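

In this assay, the methyl in place of hydrogen on an aromatic carbon gives a 1.1-fold lower number from compound 2 to compound 4 (0.04 log units; within the scatter), which means that no effect of the methyl can be read on the core of compound 2. The same kind of change therefore does not carry over at the same size from the core of compound 1 to the core of compound 2: the same change on two cores in this assay, an at least 3.1-fold higher number (0.50 log units; beyond the scatter) from compound 1 to compound 3 and a 1.1-fold lower number (0.04 log units; within the scatter) from compound 2 to compound 4, at least 3.4-fold (0.54 log units) apart, beyond the scatter of two such steps

This does not show why the two steps differ, since the cores differ and the methyl sits two atoms from the ring nitrogen only in compound 4, and the size of the earlier step is also uncertain: the limit of > 100000 nM in this assay, at which 1 of the 4 values shown sits.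

The compounds shown leave open whether a methyl at one and the same place would act alike on both cores. They also leave open whether a longer chain such as ethyl, an amine or a carboxylic acid, placed two atoms from the ring nitrogen, would shift the number in this assay.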